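Notes on the benzyl group variation in the series

The source may hold more compounds than are shown below. What is called first, only, known or untested is meant among the compounds shown, and "the series" means these compounds.

Values in a functional assay on Vas deferens for antagonist activity at Alpha-1A adrenergic receptor (Rattus norvegicus); a lower number here means a less potent compound, a higher number a more potent compound, by a factor of ten per unit of this negative logarithm:
compound 1 `COc1cccc(OC)c1OCCNCCOc1ccccc1OCc1ccccc1` gives 8.39
compound 2 `COc1cccc(OC)c1OCCNCCOc1ccccc1OCc1ccc(Cl)cc1` gives 8.17
compound 3 `COc1cccc(COc2ccccc2OCCNCCOc2c(OC)cccc2OC)c1` gives 8.3

Compound 3 holds the second highest of the three numbers, yet its gaps to compound 1 and to compound 2 both sit within the scatter, so no order among the three can be read. Compound 4 `COc1cccc(OC)c1OCCNCCOc1ccccc1OCc1ccc(OC(C)C)cc1` differs from compound 3 in 4-isopropoxyphenyl in place of 3-methoxyphenyl on a saturated chain carbon bound to an oxygen on an aromatic ring. Among the measured compounds shown here, the steps that bear on this position are the aryl exchange a number 0.13 log units higher from compound 2 to compound 3 (within the scatter) and the two substituent additions a number 0.22 log units lower from compound 1 to compound 2 (within the scatter) and a number 0.09 log units lower from compound 1 to compound 3 (within the scatter). All three stayed within the scatter, so no change beyond the scatter is expected in this assay, in either direction. Compound 4 is therefore estimated at 8.3 (range 7.8 to 8.8). The expected step of no change at the digits printed from compound 3 to compound 4 (within the scatter) is within the scatter.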

Compound 4, negative logarithm of the antagonist equilibrium constant: 8.17
Beside the measured number, compound 4's estimate is 0.13 log units above it; measured number inside the range.
By their numbers in this assay, from the lowest: compounds 2, 4, 3 and 1 (each within the scatter of the next).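

On a saturated chain carbon bound to an oxygen on an aromatic ring, 4-isopropoxyphenyl in place of 3-methoxyphenyl, with 10 heavy atoms in place of 8, leaves the number within the scatter in this assay (a number 0.13 log units lower from compound 3 to compound 4 (within the scatter)). Isopropoxy in place of hydrogen (a number 0.22 log units lower from compound 1 to compound 4 (within the scatter)) and in place of chloro (no change at the digits printed from compound 2 to compound 4 (within the scatter)) likewise gives no step beyond the scatter. No supporting evidence bears on this result. From the compounds shown here alone, whether an amine or a carboxylic acid in place of isopropoxy would step beyond the scatter remains open.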